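Cyclohexyl to Phenyl on the Amide: Predicting Compound 4

The compounds below may be only part of what the source reports. "The series", "measured", "known", "first", "only" and "open" are said of these compounds alone.

Measured so far in a functional assay on cells (Homo sapiens) for cytotoxicity, read by MTT assay, with a stated time of 72 h; a lower number here means a stronger inhibitor, a higher number a weaker inhibitor:
compound 1 `Cc1cccc(COc2cc(NC(=O)C3CCCCC3)ccc2N(C)S(C)(=O)=O)c1` gives 44200 nM;
compound 2 `Cc1cccc(COc2cc(NC(=O)c3ccccc3)ccc2N(C)S(C)(=O)=O)c1` gives 16100 nM;
compound 3 `CCCCCCOc1cc(NC(=O)C2CCCCC2)ccc1N(C)S(C)(=O)=O` gives 6980 nM.

Compound 4 `CCCCCCOc1cc(NC(=O)c2ccccc2)ccc1N(C)S(C)(=O)=O` has not yet been measured. Compound 2 differs from compound 1 by phenyl in place of cyclohexyl on a carbonyl carbon, and that step gave a 2.7-fold lower number from compound 1 to compound 2 (0.44 log units; beyond the scatter). Compound 4 differs from compound 3 by phenyl in place of cyclohexyl on a carbonyl carbon, at a place described in exactly the same words, so it is the same change made on a different core. The two cores differ in that compound 3 carries pentyl in place of 3-methylphenyl on a saturated chain carbon bound to an oxygen on an aromatic ring relative to compound 1, a change that gave a 6.3-fold lower number from compound 1 to compound 3 (0.80 log units; beyond the scatter). Within the data shown here, only one earlier example of the amide change exists, so the expectation rests on it alone. From compound 3, a step of a 2.7-fold lower number from compound 3 to compound 4 (0.43 log units; beyond the scatter) is expected in this assay, close to the earlier one. Compound 4 is therefore estimated at 2600 nM, with a likely range from 1000 nM to 7000 nM.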

Compound 4, half-maximal inhibitory concentration: 12000 nM
The estimate for compound 4 lay 4.6-fold (0.66 log units) below the measured number; measured number above the stated range.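

The cyclohexyl to phenyl change did not carry over from one core to the other in this assay: the same change on two cores in this assay, a 2.7-fold lower number (0.44 log units; beyond the scatter) from compound 1 to compound 2 and a 1.7-fold higher number (0.24 log units; within the scatter) from compound 3 to compound 4, 4.7-fold (0.67 log units) apart, beyond the scatter of two such steps

On the newer core the change gives a 1.7-fold higher number from compound 3 to compound 4 (0.24 log units; within the scatter), and pentyl in place of 3-methylphenyl, with phenyl on the amide, gives a 1.3-fold lower number from compound 2 to compound 4 (0.13 log units; within the scatter), so that change does not carry over unaltered either: the same change on two cores in this assay, a 6.3-fold lower number (0.80 log units; beyond the scatter) from compound 1 to compound 3 and a 1.3-fold lower number (0.13 log units; within the scatter) from compound 2 to compound 4, 4.7-fold (0.67 log units) apart, beyond the scatter of two such steps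

This shows that, in these four compounds, the size of each step depends on the group at the other place, but it does not show why, or how any further core would behave.

The compounds shown leave open how a pyridine ring or a cyclopentyl group on the carbonyl carbon would behave. They also leave open the effect of a longer chain on the oxygen.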